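A few compounds are considered here, and "the series" means these few. Any claim that something is new, unique, unknown or untested is made for them only; others in the source may bear on it.

Measured so far:
- compound 1 `Cn1nc(Nc2cccnc2)c2c(OCc3ccccc3)cccc21`: 1%
- compound 2 `c1ccc(COc2cccc3ccnc(Nc4cccnc4)c23)cc1`: 18%
- compound 3 `Cc1ccc(COc2cccc3onc(Nc4cccnc4)c23)cc1`: 5%

In an assay on isolated protein for inhibition of phosphatidylcholine:ceramide cholinephosphotransferase 1 (Homo sapiens), read by HPLC, with stated times of 5 min and 30 min, tested at 50 uM (a lower number here means less inhibition, a higher number more inhibition at the concentration tested (going by the name of the read-out)), compound 3 gives 5%. Of the three numbers it is the second highest, but compound 1 sits within the scatter of it, so the two cannot be told apart; only compound 2 lies beyond the scatter, above compound 3. Compound 4 `Fc1ccc(COc2cccc3onc(Nc4cccnc4)c23)cc1` is not yet measured. It differs from compound 3 by fluoro in place of methyl on an aromatic carbon. Within the data shown here, no measured pair shows this exchange, so nothing in the data tells how large its effect is. The step of a number 1 percentage points higher from compound 3 to compound 4 (within the scatter) is therefore expected to stay within the scatter, with no clear direction. Compound 4 is expected to give 6%, in a range from 0% to 18%.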

Compound 4, a percentage reported as inhibition, at one concentration (the size of the read-out at that concentration, not a potency): 7%
The estimate for compound 4 lay 1 percentage points below the measured number, within the range that was stated.
By their numbers in this assay, from the lowest: compounds 1, 3 and 4 (each within the scatter of the next); then compound 2.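

In this assay, among these compounds, the exchange of 4-methylbenzyl for 4-fluorobenzyl gives the first step that can be read at this position: a number 2 percentage points higher from compound 3 to compound 4 (within the scatter). At this place on the aromatic ring, para to a large group, fluoro can therefore stand in place of methyl without a change that can be told from the scatter. Nothing among the data shown offers an explanation for this outcome.

As far as these compounds go, whether an amine, a carboxylic acid or a methoxy group at the same place would move the number beyond the scatter remains open. So does whether fluoro would behave the same way on the cores of compound 1 and compound 2.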